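This account rests on a few compounds, and the source may have more. Where it says the series, first, only, none or still open, it means among the compounds named here.

Working notes on the series.

Compound 2 `Cc1ccc(S(C)(=O)=O)c(NCC2=NCCN2)c1` gives 3470 nM in an assay for binding affinity to Alpha-1B adrenergic receptor (Homo sapiens), read by radioligand binding; on this read-out higher numbers stand for weaker inhibition and lower numbers for stronger inhibition. Compound 1 `CSc1ccc(C)cc1NCC1=NCCN1` carries the change methylsulfanyl in place of methylsulfonyl on an aromatic carbon relative to compound 2, and in this assay compound 1 gives 123 nM, a step of a 28-fold lower number from compound 2 to compound 1 (1.45 log units; beyond the scatter). Compound 3 `CS(=O)(=O)c1ccc(Cl)cc1NCC1=NCCN1` differs from compound 2 by chloro in place of methyl on an aromatic carbon; in this assay compound 3 gives 2950 nM, a step of a 1.2-fold lower number from compound 2 to compound 3 (0.07 log units; within the scatter), so the two sulfonyl compounds sit close together.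

Compound 4 `CSc1ccc(Cl)cc1NCC1=NCCN1` is not yet measured in this assay. Its difference from compound 3 is methylsulfanyl in place of methylsulfonyl on an aromatic carbon, the same kind of change as that from compound 2 to compound 1, but the surroundings differ: here the site is para to a chloro group, whereas in the earlier pair it is para to a methyl group. Going by the values given here, with only one measured example of this change, the expectation for compound 4 rests on that single pair. Starting from compound 3, a step of a 27-fold lower number from compound 3 to compound 4 (1.43 log units; beyond the scatter) is expected for compound 4, set beside the measured step of a 28-fold lower number from compound 2 to compound 1 (1.45 log units; beyond the scatter). On this basis compound 4 is estimated at 110 nM, with a range from 40 nM to 300 nM.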

Compound 4, inhibition constant: 69.2 nM
Compound 4: the middle estimate sits 1.6-fold (0.20 log units) above what was measured; the measured number falls inside the stated range.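

In this assay, methylsulfanyl in place of methylsulfonyl gives a 43-fold lower number from compound 3 to compound 4 (1.63 log units; beyond the scatter), so the large step seen on the core of compound 2 recurs where chloro stands in place of methyl, and the two steps do not differ beyond the scatter: the same change on two cores in this assay, a 28-fold lower number (1.45 log units; beyond the scatter) from compound 2 to compound 1 and a 43-fold lower number (1.63 log units; beyond the scatter) from compound 3 to compound 4, 1.5-fold (0.18 log units) apart, within the scatter of two such steps

Chloro in place of methyl gives a 1.8-fold lower number from compound 1 to compound 4 (0.25 log units; within the scatter), and this small step likewise carries over between the sulfonyl and the sulfanyl compounds: the same change on two cores in this assay, a 1.2-fold lower number (0.07 log units; within the scatter) from compound 2 to compound 3 and a 1.8-fold lower number (0.25 log units; within the scatter) from compound 1 to compound 4, 1.5-fold (0.18 log units) apart, within the scatter of two such steps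

This shows that the two changes behave independently across these four compounds only; it rests on one pair per comparison, covers only chloro and methyl as the second group, and gives no reason for the size of the sulfur step.

The compounds shown leave open whether the sulfur step would hold with a methoxy group or an amine in place of chloro or methyl. They also leave open how a longer chain on the sulfur, such as ethylsulfanyl, would read in this assay.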